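A few compounds are considered here, and "the series" means these few. Any claim that something is new, unique, unknown or untested is made for them only; others in the source may bear on it.

Three compounds have so far been measured in a functional assay on the whole organism with Mus musculus as the target, in the rotarod test; on this read-out higher numbers stand for an effect only at larger amounts of compound and lower numbers for an effect already at smaller amounts:

Compound 1 `NC(=O)/C=C1\CCc2ccc(Cl)cc21`: 221 mg/kg
Compound 2 `NC(=O)/C=C1\CCc2c1ccc(F)c2F`: 50 mg/kg
Compound 3 `Cc1cccc2c1CC/C2=C\C(=O)NC1CC1`: 64 mg/kg

Compound 1 has the highest number of the three in this assay. Compound 3 comes nearest to it and compound 2 lies furthest away; both gaps are beyond the usual scatter. Compound 4 `NC(=O)/C=C1\CCc2ccc(F)cc21` has not yet been measured. It differs from compound 1 only in that (fluoro in place of chloro on an aromatic carbon). For the measured compounds named here, no pair of measured compounds shows this exact change, so its size is unknown. Compound 2, which also carries fluoro groups on the shared core, gives the lowest number, but its difference from compound 1 is not a single change. A modest step toward a lower number, or none beyond the scatter, is expected in this assay, estimated as a 1.5-fold lower number from compound 1 to compound 4 (0.17 log units; within the scatter). Compound 4 is estimated at 150 mg/kg, within a range from 60 mg/kg to 350 mg/kg.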

Compound 4, dose for half-maximal effect: 90 mg/kg
For compound 4 the middle estimate is 1.7-fold (0.22 log units) above the measured one; low and high end bracket the measured number.
By their numbers in this assay, from the lowest: compounds 2, 3 and 4 (each within the scatter of the next); then compound 1.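

In this assay, for the compounds shown here, exchanging the chloro group on the aromatic carbon for a fluoro group, as the single change, gives a 2.5-fold lower number from compound 1 to compound 4 (0.39 log units; beyond the scatter). Going by these compounds alone, this is the first direct sign that the number responds to which halogen sits at this position, as no two earlier compounds differed in only one place. Nothing measured here accounts for the step.

Still open, from the compounds shown here alone, is whether a methyl group, a methoxy group or an amine at this carbon would shift the number further. It is also unclear whether the same swap would give a similar step at other positions on the shared core.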